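Compound 2 and a chlorophenyl exchange

The source may hold more compounds than are shown below. What is called first, only, known or untested is meant among the compounds shown, and "the series" means these compounds.

Compound 1 `CN1C/C(=C\c2ccc(C(F)(F)F)cc2)C(=O)/C(=C/c2ccccc2F)C1` gives 5930 nM
Compound 2 `COc1cc(/C=C2\CN(C)C/C(=C\c3cc(OC)c(OC)c(OC)c3)C2=O)cc(OC)c1` gives 720 nM

In a functional assay on THP-1 cells (Homo sapiens) for cytotoxicity, read by MTT assay, with a stated time of 24 h (a higher number here means a weaker inhibitor, a lower number a stronger inhibitor), compound 2 at 720 nM holds the lower of the two numbers, and compound 1 lies above it by more than the usual scatter. Compound 3 `COc1cc(/C=C2\CN(C)C/C(=C\c3ccc(Cl)cc3)C2=O)cc(OC)c1OC` has not yet been measured. It departs from compound 2 in one place: 4-chlorophenyl in place of 3,5-dimethoxyphenyl on a double-bonded chain carbon bound to a double-bonded ring carbon. In words, 4-chlorophenyl stands in place of 3,5-dimethoxyphenyl on a double-bonded chain carbon bound to a double-bonded ring carbon. Going by the values given here, no pair of measured compounds differs in a single place, so the data give no direct measure of this exchange. Among the compounds with values here, the only guide is compound 1 at 5930 nM, which carries no methoxy group. A move in this assay toward a higher number, and so a weaker inhibitor, is therefore expected, probably beyond the scatter but stopping short of compound 1. The expected change is a 2.5-fold higher number from compound 2 to compound 3 (0.40 log units; beyond the scatter). For compound 3 the estimated value is 1800 nM, with the measurement expected between 500 nM and 6000 nM.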

Compound 3, half-maximal inhibitory concentration: 7200 nM
Compound 3: middle estimate off by 4.0-fold (0.60 log units), on the low side; the whole stated range lies below it.
By their numbers in this assay, from the lowest: compound 2; then compounds 1 and 3 (each within the scatter of the next).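

The exchange of 3,5-dimethoxyphenyl for 4-chlorophenyl on a double-bonded chain carbon bound to a double-bonded ring carbon now has a direct measure: in this assay it gives a 10-fold higher number from compound 2 to compound 3 (1.00 log units; beyond the scatter), a step beyond the scatter. Going by these compounds alone, compounds 2 and 3 are the first measured pair to differ in a single place, and they show that this position alone can move the number by that much while the rest of the molecule stays the same. The group that leaves counts two hydrogen-bond acceptors and the one that enters counts none, but nothing at hand gives a cause for the step.

The exchange removes both methoxy groups and adds the chlorine in one move, so the compounds shown leave open which of these changes carries the step, and a plain phenyl or a 4-methoxyphenyl at this place would begin to separate them. On these data alone, it also remains open whether a ring bearing an amine or a carboxylic acid at this place would give a lower or a higher number than compound 2.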